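The source may hold more compounds than are shown below. What is called first, only, known or untested is meant among the compounds shown, and "the series" means these compounds.

In a functional assay on NCI-H1975 cells (Homo sapiens) for antiproliferative activity, read by CCK-8 assay, with a stated time of 72 h (a lower number here means a stronger inhibitor of growth, a higher number a weaker inhibitor of growth), three compounds have been measured:

compound 1 `CCC1C(=O)N(C)c2cnc(-n3ccc4cc(C(=O)NC(C)C)ccc43)nc2N1c1ccn(C)n1`: 12200 nM
compound 2 `CCC1C(=O)N(C)c2cnc(-n3ccc4cc(C(=O)NC)ccc43)nc2N1c1ccn(C)n1`: 35700 nM
compound 3 `CCCNC(=O)c1ccc2c(ccn2-c2ncc3c(n2)N(c2ccn(C)n2)C(CC)C(=O)N3C)c1`: 11000 nM

Compound 3 has the lowest of the three numbers, but a 1.1-fold lower number from compound 1 to compound 3 (0.04 log units; within the scatter) does not separate it from compound 1. Only compound 2 stands apart, with a 3.2-fold lower number from compound 2 to compound 3 (0.51 log units; beyond the scatter).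

Compound 4 `CCNC(=O)c1ccc2c(ccn2-c2ncc3c(n2)N(c2ccn(C)n2)C(CC)C(=O)N3C)c1` has not yet been measured. It differs from compound 3 by hydrogen in place of methyl on a saturated chain carbon, two bonds along the chain from an amide-type nitrogen. This turns propyl into ethyl, while compound 2 carries methyl at that nitrogen.

Within the data shown here, two measured steps bear on this change: a 3.2-fold lower number from compound 2 to compound 3 (0.51 log units; beyond the scatter), which spans it, and a 2.9-fold higher number from compound 1 to compound 2 (0.47 log units; beyond the scatter), which is of similar size. Compound 4 covers only part of the change from propyl to methyl, so a smaller step towards a higher number is expected in this assay, probably within the scatter. The expected step is a 1.7-fold higher number from compound 3 to compound 4 (0.24 log units; within the scatter). The estimated value for compound 4 is 19000 nM, with an expected range of 10000 nM to 36000 nM.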

Compound 4, concentration for 50% growth inhibition: "not active" (no number reported)
The entry for compound 4 holds no number, so the estimate cannot be set against anything.
By their numbers in this assay, from the lowest: compounds 3 and 1 (each within the scatter of the next); then compound 2.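

Among these compounds, compound 4 is recorded as not active in this assay with no number, so no step between it and compound 3 or any other compound can be read. Nothing here bears on this result. The compounds shown leave open how ethyl compares numerically with propyl at this amide nitrogen.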